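Sulfone in place of thioether on a bicyclic triazole side chain

The source may hold more compounds than are shown below. What is called first, only, known or untested is meant among the compounds shown, and "the series" means these compounds.

Measured so far:
compound 1 `CCSCCC12CCC(c3nnc(-c4ccccc4C(F)(F)F)n3C)(CC1)CC2` – in an assay on CHO-K1 cells for inhibition of 11-beta-hydroxysteroid dehydrogenase type 2 (Homo sapiens), read by scintillation proximity assay (on this read-out lower numbers stand for stronger inhibition and higher numbers for weaker inhibition), compound 1 gives > 4000 nM, which is a limit of the assay and not a number.
compound 2 `Cn1c(-c2ccccc2C(F)(F)F)nnc1C12CCC(CCS(C)(=O)=O)(CC1)CC2` – in this assay compound 2 gives > 4000 nM, again a limit rather than a number.

Compound 1 therefore stands only at a limit; nothing shown places it on a measurable point. Within the data shown here, the single measured step, a step that the two limits leave unreadable from compound 1 to compound 2, is unreadable because the limit of > 4000 nM in this assay, at which 2 of the 2 values shown sit, holds both ends of it.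

Compound 3 `Cn1c(-c2ccccc2C(F)(F)F)nnc1C12CCC(CCS(=O)(=O)C(C)(C)C)(CC1)CC2` differs from compound 1 by (tert-butyl)sulfonyl in place of ethylsulfanyl on a saturated chain carbon, two bonds along the chain from a saturated ring carbon. The step from compound 1 to compound 2 bears on this change, since it also replaces the ethylsulfanyl group with a sulfonyl group in the same place, yet its size cannot be read. What the data support is that a sulfonyl at this position has not produced a measurable value.

The expected outcome is that compound 3 again reaches only the limit in this assay, with an estimated value of 8000 nM in the range 3000 nM to 30000 nM, so that a step that the limit leaves unreadable from compound 1 to compound 3 is expected to be no step beyond the scatter.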

Compound 3, half-maximal inhibitory concentration: > 4000 nM
Compound 3: only a limit was reported; the forecaster's own chance of this, stated with the estimate: 80%; the middle value lies beyond the limit too.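

In this assay compound 3 gives > 4000 nM as a limit of the assay and not a number. The steps among compound 1, compound 2 and compound 3 therefore cannot be read, because all three values end at the same limit: the limit of > 4000 nM in this assay, at which 3 of the 3 values shown sit. Still open, on these data alone, is whether the three compounds differ at all in this assay and how far.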